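Cytotoxicity notes: triazole-linked cinnamic acids, nitrile analogue pending

This account rests on a few compounds, and the source may have more. Where it says the series, first, only, none or still open, it means among the compounds named here.

The series shares one core, carried in compound 1 `COc1ccccc1-n1cc(COc2c(/C=C\C(=O)O)ccc(OC)c2CC=C(C)C)nn1` and compound 2 `COc1ccc(/C=C\C(=O)O)c(OCc2cn(-c3ccccc3)nn2)c1CC=C(C)C`. Among the compounds with values here, in a functional assay on A549 cells (Homo sapiens) for cytotoxicity, read by MTT assay, with a stated time of 24 h (a higher number here means a weaker inhibitor, a lower number a stronger inhibitor), compound 1 gives 43000 nM, and compound 2 gives 40500 nM; the step of a 1.1-fold lower number from compound 1 to compound 2 (0.03 log units; within the scatter) is the only measured comparison. Compound 3 `COc1ccc(/C=C\C(=O)O)c(OCc2cn(-c3ccccc3C(=O)N3CCC(O)C3)nn2)c1CC=C(C)C` gives "not determined" (no result reported) in this assay, so it stands nowhere on these numbers. Within the data shown here, compound 4 `COc1ccc(/C=C\C(=O)O)c(OCc2cn(-c3ccccc3C#N)nn2)c1CC=C(C)C` differs from compound 3 by cyano in place of (3-hydroxypyrrolidin-1-yl)carbonyl on an aromatic carbon, a change at the same ring as the one probed from compound 1 to compound 2. Among the measured compounds shown here, no measured step bears on the loss of the (3-hydroxypyrrolidin-1-yl)carbonyl group; the only known step at that ring was within the scatter, so no shift beyond the scatter is assumed. Compound 4 is therefore expected near the measured pair, at 40000 nM, within 15000 nM to 110000 nM.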

Compound 4, half-maximal inhibitory concentration: 38600 nM
The estimate for compound 4 lay 1.0-fold (0.02 log units) above the measured number, within the range that was stated.
By their numbers in this assay, from the lowest: compounds 4, 2 and 1 (each within the scatter of the next).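

In this assay, cyano in place of hydrogen on this aromatic carbon gives a 1.0-fold lower number from compound 2 to compound 4 (0.02 log units; within the scatter) and cyano in place of methoxy gives a 1.1-fold lower number from compound 1 to compound 4 (0.05 log units; within the scatter) as the step. The position therefore now reads flat across a third group, and the nitrile, absent from the earlier pair, separates from neither hydrogen nor methoxy. Nothing measured here accounts for this flat reading. Open, on these data alone, is whether an amine, a carboxylic acid or a longer chain on this carbon would leave the level unchanged, and where the (3-hydroxypyrrolidin-1-yl)carbonyl group stands.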